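This account rests on a few compounds, and the source may have more. Where it says the series, first, only, none or still open, it means among the compounds named here.

Compound 1 `Cc1cc2[nH]nc(N)c2c(=O)[nH]1` is measured in an assay on isolated protein for inhibition of ribosomal protein S6 kinase alpha-5 (Homo sapiens), read by mobility shift assay, tested at 30 uM (a lower number here means less inhibition, a higher number more inhibition at the concentration tested (going by the name of the read-out)), and there compound 1 gives 56%. Compound 2 `Cc1cc2c(c(N)nn2C)c(=O)[nH]1` shares this core; in this assay compound 2 gives 4%. The step of a number 52 percentage points higher from compound 2 to compound 1 (beyond the scatter) follows the change (hydrogen in place of methyl on an aromatic nitrogen). Compound 3 `Cc1cc2c(cn1)c(N)nn2C` is built on a different core, and in this assay compound 3 gives -2%; the difference between the two cores is not broken down here. Compound 4 `Cc1cc2[nH]nc(N)c2cn1` has not been measured; it arises from compound 3 by hydrogen in place of methyl on an aromatic nitrogen, the same change that gave compound 1 from compound 2. Among the compounds with values here, a step of a number 32 percentage points higher from compound 3 to compound 4 (beyond the scatter) is expected, resting on the one seen as a number 52 percentage points higher from compound 2 to compound 1 (beyond the scatter), but held smaller and wider because compound 3 sits on another core than compound 2 and compound 3 gives -2%. Compound 4 is therefore estimated to give 30%.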

Compound 4, a percentage reported as inhibition, at one concentration (the size of the read-out at that concentration, not a potency): 13%
Estimate against measurement, compound 4: 17 percentage points above; the measured number falls inside the stated range.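

In this assay, hydrogen in place of methyl on an aromatic nitrogen again gives a higher number, a number 15 percentage points higher from compound 3 to compound 4 (beyond the scatter). The direction of the change holds on both cores, but its size does not carry over: the same change on two cores in this assay, a number 52 percentage points higher (beyond the scatter) from compound 2 to compound 1 and a number 15 percentage points higher (beyond the scatter) from compound 3 to compound 4, 37 percentage points apart, beyond the scatter of two such steps The step on one core therefore does not fix the size of the step on the other, and two cores alone do not show what sets that size or whether the direction would hold on a third core.

The compounds shown leave open what an ethyl group or a longer chain on that aromatic nitrogen would give. They also leave open how an acetyl group on the amino group would affect the numbers on either core.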